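Sulfonamide aryl variation in a cyclopropyl ketone series

A few compounds are considered here, and "the series" means these few. Any claim that something is new, unique, unknown or untested is made for them only; others in the source may bear on it.

Measured compounds:
compound 1 `O=C(c1ccc(OCCCN2CC[C@H](NS(=O)(=O)c3cccc(F)c3)C2)cc1)C1CC1`, 1600 nM
compound 2 `O=C(c1ccc(OCCCN2CC[C@H](NS(=O)(=O)c3ccc(Br)cc3)C2)cc1)C1CC1`, 290 nM

Both compounds share one core and differ only in the aryl group on the sulfonyl sulfur. In an assay on isolated protein for binding affinity to histamine H2 receptor (Homo sapiens) (a higher number here means a weaker inhibitor, a lower number a stronger inhibitor), compound 1 gives the higher of the two numbers, and compound 2 sits a 5.5-fold lower number from compound 1 to compound 2 (0.74 log units; beyond the scatter) away from it, a change that stands beyond the scatter.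

Compound 3 `N#Cc1ccc(S(=O)(=O)N[C@H]2CCN(CCCOc3ccc(C(=O)C4CC4)cc3)C2)cc1` is not yet measured. It differs from compound 1 in one place: 4-cyanophenyl in place of 3-fluorophenyl on a sulfonyl sulfur. For the measured compounds named here, the one measured step that bears on this change is the one from compound 1 to compound 2, where 4-bromophenyl replaced 3-fluorophenyl at the same sulfonyl sulfur and the number fell by a 5.5-fold lower number from compound 1 to compound 2 (0.74 log units; beyond the scatter). The change to compound 3 likewise swaps the 3-fluorophenyl for a 4-substituted phenyl, though the entering group is a 4-cyanophenyl rather than 4-bromophenyl, so the size of the effect is less certain.

On that basis a step of a 3.2-fold lower number from compound 1 to compound 3 (0.51 log units; beyond the scatter) in this assay is expected, that is a lower number than for compound 1, probably smaller than the step to compound 2. The estimate for compound 3 in this assay is 500 nM, with a range from 150 nM to 1600 nM.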

Compound 3, inhibition constant: 1600 nM
The estimate for compound 3 lay 3.2-fold (0.51 log units) below the measured number; the range from low to high includes it.
By their numbers in this assay, from the lowest: compound 2; then compounds 1 and 3 (each within the scatter of the next).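

In this assay, exchanging the 3-fluorophenyl on the sulfonyl sulfur for 4-cyanophenyl gives no change at the digits printed from compound 1 to compound 3 (within the scatter), so a 4-substituted phenyl at this place does not by itself bring the lower number seen with compound 2. Cyano in place of bromo on an aromatic carbon gives a 5.5-fold higher number from compound 2 to compound 3 (0.74 log units; beyond the scatter), which shows that the identity of the group on the ring matters at this position and that, among these three compounds, only the 4-bromophenyl stands apart. Nothing available here explains why the 4-bromophenyl and 4-cyanophenyl groups differ in this way.

The compounds shown do not separate the contribution of bromo from that of its ring position, so it remains open whether 3-bromophenyl would keep the lower number or 4-fluorophenyl would share it. As far as these compounds go, it is also open whether the lower number extends to other groups at the same place, such as 4-chlorophenyl, 4-methylphenyl or 4-methoxyphenyl, or to a non-aromatic group such as cyclohexyl on the sulfonyl sulfur.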